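The compounds below may be only part of what the source reports. "The series", "measured", "known", "first", "only" and "open" are said of these compounds alone.

In an assay on HEK293 cells for displacement of a labelled ligand from melanin-concentrating hormone receptor 1 (Homo sapiens) (a higher number here means a weaker inhibitor, a lower number a stronger inhibitor), compound 1, `O=C(CC1CCN(Cc2ccn(-c3ccc(C(F)(F)F)cc3)c2)CC1)N(CCCO)Cc1ccc(F)cc1`, gives 4 nM. Going by the values given here, compound 2, `O=C(NCC1(O)CCCCC1)C1CCN(Cc2ccn(-c3ccc(C(F)(F)F)cc3)c2)CC1`, gives 40 nM in this assay, the higher of the two numbers known so far; its nearest neighbour is compound 1, whose number is lower by a margin that lies beyond the usual scatter. Compound 3, `O=C(NCc1ccc(Cl)cc1O)C1CCN(Cc2ccn(-c3ccc(C(F)(F)F)cc3)c2)CC1`, has not yet been measured. It differs from compound 2 in a single place: 4-chloro-2-hydroxyphenyl in place of 1-hydroxycyclohexyl on a saturated chain carbon bound to an amide-type nitrogen. Among the compounds with values here, no measured pair shows this exchange, so its effect cannot be read from the two numbers at hand, and nothing among the measured compounds ties the change to a move in either direction. The account therefore expects only a modest shift, leaning toward a lower number for compound 3, and the expected step is a 2.0-fold lower number from compound 2 to compound 3 (0.30 log units; within the scatter), a size that could still fall within the scatter of this assay. Compound 3 is accordingly estimated at 20 nM in this assay, with a plausible range from 5 nM to 80 nM.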

Compound 3, half-maximal inhibitory concentration: 22 nM
Estimate against measurement, compound 3: 1.1-fold (0.04 log units) below; measured number inside the range.
By their numbers in this assay, from the lowest: compound 1; then compounds 3 and 2 (each within the scatter of the next).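

In this assay the exchange at this place, on a saturated chain carbon bound to an amide-type nitrogen, gives a 1.8-fold lower number from compound 2 to compound 3 (0.26 log units; within the scatter) and so leaves compound 2 and compound 3 indistinguishable in this measurement. The result shows that this position tolerates a six-membered aromatic ring bearing chlorine and hydroxyl in place of a six-membered non-aromatic ring of carbon only, with the donor and acceptor counts of the two groups matching and the number staying within the scatter. No measurement shown offers an explanation for this outcome, and compound 1 differs from both compounds in more than one place, so it adds nothing to the reading of this exchange.

What remains open is how much the chlorine and the hydroxyl of the 4-chloro-2-hydroxyphenyl group each contribute, since a plain benzyl group or an amine in place of the hydroxyl does not appear among these compounds. Also open, on these data alone, is what a longer chain between the ring and the amide-type nitrogen would do to the number in this assay for this series.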